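The source may hold more compounds than are shown below. What is called first, only, known or untested is meant among the compounds shown, and "the series" means these compounds.

In a functional assay on HL-60 cells (Homo sapiens) for inhibition, read by MTT assay, with a stated time of 72 h (a higher number here means a weaker inhibitor, a lower number a stronger inhibitor), compound 1 `Cc1nc(-c2ccccc2)c(C(=O)N2CCN(c3cccc(C(N)=O)c3)CC2)o1` gives 71 nM and compound 3 `Cc1nc(-c2ccccc2)c(C(=O)N2CCN(c3ccc(Cl)c(Cl)c3)CC2)o1` gives 124 nM. These two values stand level, with a 1.7-fold higher number from compound 1 to compound 3 (0.24 log units; within the scatter). Compound 2 `Cc1nc(-c2ccccc2)c(C(=O)N2CCN(c3ccc(F)cc3)CC2)o1` reads > 1000 nM, which is a limit of the assay and not a number.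

Compound 4 `Cc1nc(-c2ccccc2)c(C(=O)N2CCN(c3cccc(F)c3)CC2)o1` is still unmeasured, and it carries 3-fluorophenyl in place of 3,4-dichlorophenyl on an amine nitrogen in a ring. The closest evidence is compound 2, a fluorophenyl analogue, with an at least 8.0-fold lower number from compound 2 to compound 3 (0.90 log units; beyond the scatter). Its other measured step is an at least 14-fold higher number from compound 1 to compound 2 (1.14 log units; beyond the scatter). On the strength of compound 2 and an at least 8.0-fold lower number from compound 2 to compound 3 (0.90 log units; beyond the scatter), a higher number is expected in this assay, though the size is uncertain, with a 3.2-fold higher number from compound 3 to compound 4 (0.51 log units; beyond the scatter) as the expected step. For compound 4 the estimated value is 400 nM, with an expected range from 130 nM to 1300 nM.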

Compound 4, half-maximal inhibitory concentration: 45 nM
Compound 4: middle estimate off by 8.9-fold (0.95 log units), on the high side; the measured number lies below the stated range.
By their numbers in this assay, from the lowest: compounds 4, 1 and 3 (each within the scatter of the next, the first and the last beyond it). At a limit, above all of these: compound 2.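

Fluorophenyl as such does not account for the weak reading of compound 2: in this assay, 3-fluorophenyl in place of 4-fluorophenyl gives an at least 22-fold lower number from compound 2 to compound 4 (1.34 log units; beyond the scatter). That reading is a limit of the assay and not a number: the limit of > 1000 nM in this assay, at which 1 of the 4 values shown sits.

On the amine nitrogen in a ring, 3-fluorophenyl in place of 3,4-dichlorophenyl gives a 2.8-fold lower number from compound 3 to compound 4 (0.44 log units; beyond the scatter), while fluoro in place of carbamoyl gives a 1.6-fold lower number from compound 1 to compound 4 (0.20 log units; within the scatter), so those two compounds stand level.

Still open, going by these compounds, is whether a methoxy or an amine in place of the fluoro of 3-fluorophenyl would read alike. On these data alone, an unsubstituted phenyl on the same nitrogen is also open.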